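This account rests on a few compounds, and the source may have more. Where it says the series, first, only, none or still open, it means among the compounds named here.

In a functional assay on HepG2 cells (Homo sapiens) for inhibition, read by MTT assay, with a stated time of 48 h (a higher number here means a weaker inhibitor, a lower number a stronger inhibitor), compound 3 (`COc1cc(-c2nnc(SCc3ccc(F)cc3)n2-c2ccc(N(C)C)cc2)cc(OC)c1OC`) gives 26400 nM as its reading, within the scatter of compound 1 (`COc1ccc(-n2c(SCc3ccc(F)cc3)nnc2-c2cc(OC)c(OC)c(OC)c2)cc1`) at 35000 nM as its reading. That pair shows a 1.3-fold lower number from compound 1 to compound 3 (0.12 log units; within the scatter) for dimethylamino in place of methoxy on an aromatic carbon, a change elsewhere in the molecule that offers little guidance here. Compound 2 (`COc1cc(-c2nnc(S)n2-c2ccc(N(C)C)cc2)cc(OC)c1OC`) shows only a limit of the assay, > 60000 nM in this case. Among the measured compounds shown here, putting 4-fluorobenzyl in place of hydrogen on the sulfur gives an at least 2.2-fold lower number from compound 2 to compound 3 (0.35 log units; beyond the scatter) as the only measured step at this place. Compound 4 (`COc1ccc(NC(=O)CSc2nnc(-c3cc(OC)c(OC)c(OC)c3)n2-c2ccc(N(C)C)cc2)cc1`) changes the same region: (4-methoxyphenyl)carbamoyl in place of 4-fluorophenyl on a saturated chain carbon bound to a sulfur with (4-methoxyphenyl)carbamoyl in place of 4-fluorophenyl on a saturated chain carbon bound to a sulfur. For the measured compounds named here, both compounds keep an aromatic ring in this group, and no measured step swaps one such group for another. The expected change in this assay is therefore small and of uncertain direction, estimated as a 1.3-fold lower number from compound 3 to compound 4 (0.12 log units; within the scatter) for now. For compound 4 the estimated value is 20000 nM with an expected range of 6000 nM to 60000 nM in this assay.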

Compound 4, half-maximal inhibitory concentration: > 60000 nM
Compound 4 ended at the assay's limit; the forecaster's own chance of this, stated with the estimate: 15%; at least 3.0-fold (0.47 log units) between middle value and limit.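

In this assay, among the compounds shown here, this is the first measured exchange of one aromatic group for another on a saturated chain carbon bound to a sulfur, and it gives an at least 2.2-fold higher number from compound 3 to compound 4 (0.35 log units; beyond the scatter). Keeping a six-membered aromatic ring in the group is therefore not enough to preserve the reading of compound 3, so this position does respond to what the group carries. The step from compound 2 to compound 4 cannot be read, as both compounds sit at the same limit: the limit of > 60000 nM in this assay, at which 2 of the 4 values shown sit.

The carbamoyl link and the 4-methoxy group enter together, so it remains open which of them accounts for the higher number. A 4-methoxybenzyl group on the sulfur, tested against compound 3, would address the methoxy group without the carbamoyl link.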